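(3-(Dimethylamino)propoxy)methyl in Place of Ethoxycarbonyl

The source may report more compounds than this note shows. Statements on the series, on what has been measured and on what is new or still open speak of the compounds shown alone.

Three compounds sharing one core were tested in a functional assay on HeLa cells (Homo sapiens) for cytotoxicity, read by neutral red uptake, with a stated time of 3 days; on this read-out higher numbers stand for weaker inhibition and lower numbers for stronger inhibition. Compound 1 `Cc1c(F)c(N)c2c(=O)cc(-c3ccc(N)c(F)c3)oc2c1F` carries a methyl group on the core; in this assay compound 1 gives > 100000 nM, which is a limit of the assay and not a number. Compound 2 `CCc1c(F)c(N)c2c(=O)cc(-c3ccc(N)c(F)c3)oc2c1F` bears an ethyl group in its place, and in this assay compound 2 gives > 100000 nM, again only a limit. Compound 3 `CCOC(=O)c1c(F)c(N)c2c(=O)cc(-c3ccc(N)c(F)c3)oc2c1F` carries an ethoxycarbonyl group, and in this assay compound 3 gives > 100000 nM, also a limit. Compound 3 therefore stands exactly where the other two stand, at the limit of > 100000 nM in this assay, at which 3 of the 3 values shown sit. The steps a step that the two limits leave unreadable from compound 1 to compound 2, a step that the two limits leave unreadable from compound 1 to compound 3 and a step that the two limits leave unreadable from compound 2 to compound 3 are all of unreadable size, each running from one limit to another.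

Compound 4 `CN(C)CCCOCc1c(F)c(N)c2c(=O)cc(-c3ccc(N)c(F)c3)oc2c1F` differs from compound 3 by (3-(dimethylamino)propoxy)methyl in place of ethoxycarbonyl on an aromatic carbon. Going by the values given here, no measured step bears readably on this change; the only guidance is that all three neighbours rest at the limit. The step to compound 4 is expected to be a number no higher from compound 3 to compound 4 (the limit leaves the size open), with no direction readable. Compound 4 is expected to give 100000 nM in this assay, within 30000 nM to 300000 nM, and most likely to be reported once more as a limit.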

Compound 4, half-maximal inhibitory concentration: 12000 nM
Beside the measured number, compound 4's estimate is 8.3-fold (0.92 log units) above it; measured number outside the range, below it.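

In this assay, going by these compounds alone, compound 4 gives 12000 nM, the first readable number at this position, on the aromatic carbon ortho to two fluoro groups. The change read directly is an at least 8.3-fold lower number from compound 3 to compound 4 (0.92 log units; beyond the scatter), and the comparisons with the two alkyl compounds agree, with an at least 8.3-fold lower number from compound 2 to compound 4 (0.92 log units; beyond the scatter) and an at least 8.3-fold lower number from compound 1 to compound 4 (0.92 log units; beyond the scatter), all three steps starting from a limit of the assay and all printed as beyond the scatter. Methyl, ethyl and ethoxycarbonyl at this place cannot be told apart, as the steps among them cannot be read, and of the groups shown only (3-(dimethylamino)propoxy)methyl moves a compound off the shared limit: the limit of > 100000 nM in this assay, at which 3 of the 4 values shown sit.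

The compounds shown do not say which part of the new chain goes with the step: a propoxymethyl chain without the amine, a shorter dimethylaminoethoxymethyl chain or a morpholine in place of the dimethylamino group would separate the amine from the ether and the chain length. On these data alone, the full size of each step also stays open, and so does whether a second amine-bearing chain at this position would reach a number in this assay like that of compound 4.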